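The compounds below may be only part of what the source reports. "The series", "measured", "known", "first", "only" and "open" are said of these compounds alone.

In a physicochemical assay for lipophilicity, at pH 7.4 (a higher number here means a more lipophilic compound, a lower number a more polar compound), two related compounds have been measured. Compound 1 `Cc1cc(S(=O)(=O)NCCCC[C@@H](Nc2cc(C)c(F)c(C)c2)C(=O)NO)ccc1F` gives < 3 as a limit of the assay, not a number. Compound 2 `Cc1cc(N[C@H](CCCCNCc2cccc(F)c2)C(=O)NO)cc(C)c1F` gives < 3 as a limit too, so it has no exact position on the scale. Both measured compounds sit at this same limit (the limit of < 3 in this assay, at which 2 of the 2 values shown sit), and neither can be ranked against the other. Compound 3 `Cc1cc(N[C@H](CCCCNCc2ccc([N+](=O)[O-])cc2)C(=O)NO)cc(C)c1F` differs from compound 2 in one place: 4-nitrophenyl in place of 3-fluorophenyl on a saturated chain carbon bound to an amine nitrogen. Within the data shown here, no measured pair shows what such a swap does in this assay, so only a small step toward lower numbers is expected, none beyond the usual scatter. The estimated step that the limit leaves unreadable from compound 2 to compound 3 is therefore modest. For compound 3 the expected value is 2.7 with an estimated range from 2 to 3.2 in this assay.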

Compound 3, distribution coefficient: < 3
Compound 3 was reported as a limit; the forecaster's own chance of this, stated with the estimate: 85%; the middle value lies beyond the limit too.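

In this assay compound 3 gives < 3, which is a limit of the assay and not a number. Among these compounds, compound 2 also sits at a limit, so no step between compound 2 and compound 3 can be read. The compounds shown leave open how far 4-nitrophenyl in place of 3-fluorophenyl shifts the value.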